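Cytotoxicity notes on an imidazopyridine-derived series in HEL cells

The compounds below may be only part of what the source reports. "The series", "measured", "known", "first", "only" and "open" are said of these compounds alone.

Measured so far:
compound 1 `COc1cccc(-c2cc(C)c3ncc(CSCCc4ccccc4)n3c2)c1`: 20 ug/mL
compound 2 `COc1ccc(-c2cc(C)cn3c(CSCCc4ccccc4)cnc23)cc1`: 20 ug/mL

In an ADME assay on HEL cells (Homo sapiens) for cytotoxicity, with a stated time of 3 days (on this read-out higher numbers stand for lower toxicity in this test and lower numbers for higher toxicity in this test), compound 1 gives 20 ug/mL. Compound 2, which carries a 4-methoxyphenyl in place of the 3-methoxyphenyl, gives 20 ug/mL in this assay; the two values sit level at the digits reported, within the scatter, so no order between them is claimed. Among the compounds with values here, no step between measured compounds is available for this series beyond that pair.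

The next compound, compound 3 `Cc1cc(Br)cn2c(CSCCc3ccccc3)cnc12`, differs from compound 1 in one place: bromo in place of 3-methoxyphenyl on an aromatic carbon. Only the two measured points exist to lean on, and neither tests a change of this kind, so the expectation for compound 3 in this assay is that the step of no change at the digits printed from compound 1 to compound 3 (within the scatter) stays within the scatter, with no direction preferred. Compound 3 is therefore estimated at 20 ug/mL in this assay, in the range 7 ug/mL to 60 ug/mL.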

Compound 3, minimum cytotoxic concentration: >= 2 ug/mL
Compound 3: a limit, no number (the forecaster's own chance of this, stated with the estimate: 20%); the middle value does not contradict the limit.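

In this assay compound 3 gives >= 2 ug/mL, which is a limit and not a number. Within the data shown here, no step can therefore be read between compound 1 and compound 3. The compounds shown leave open whether bromo in place of 3-methoxyphenyl on an aromatic carbon changes the minimum cytotoxic concentration, and in which direction.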